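Rhodanine for thiazolidinedione on the aryl amide tail

A few compounds are considered here, and "the series" means these few. Any claim that something is new, unique, unknown or untested is made for them only; others in the source may bear on it.

Working notes on a short peptide-like series with a shared core and a varied aromatic amide cap. Compound 3 `CCCC[C@H](NC(=O)[C@H](CCCCN)NC(=O)[C@H](CCCNC(=N)N)NC(=O)c1ccc(/C=C2\SC(=O)N(CCCC)C2=O)cc1)C(N)=O` is the reference point. In an ADME assay for permeability, using PAMPA (on this read-out lower numbers stand for lower permeability and higher numbers for higher permeability), compound 3 gives 1.18 10^-6 cm/s. Compound 1 `CCCC[C@H](NC(=O)[C@H](CCCCN)NC(=O)[C@H](CCCNC(=N)N)NC(=O)c1ccc(/C=C2\SC(=S)N(c3ccc(Cl)cc3)C2=O)cc1)C(N)=O` carries a different aromatic amide end; in this assay compound 1 gives 1.02 10^-6 cm/s, a number that sits alongside that of compound 3, the gap between the two lying within the usual scatter. Compound 2 `CCCC[C@H](NC(=O)[C@H](CCCCN)NC(=O)[C@H](CCCNC(=N)N)NC(=O)c1ccccc1)C(N)=O`, which has the plain aromatic amide end, is reported in this assay as "impermeable" (no number reported), with no number given. Among the measured compounds shown here, compound 3 therefore shares the measurable end of the set with compound 1, and no step between measured pairs that differ in one place is available.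

Compound 4 `CCCC[C@H](NC(=O)[C@H](CCCCN)NC(=O)[C@H](CCCNC(=N)N)NC(=O)c1ccc(/C=C2\SC(=S)N(CCCC)C2=O)cc1)C(N)=O` is the next member. It differs from compound 3 by a group of 12 heavy atoms (8 carbon, 1 nitrogen, 1 oxygen, 2 sulfur; one five-membered non-aromatic ring with 2 hetero atoms) in place of a group of 12 heavy atoms (8 carbon, 1 nitrogen, 2 oxygen, 1 sulfur; one five-membered non-aromatic ring with 2 hetero atoms), on an aromatic carbon. For the measured compounds named here, no measured step exists for this exchange. Given that compound 1 gives 1.02 10^-6 cm/s with the same five-membered ring type that enters in compound 4, and that this matches compound 3 within the scatter, the step of a 1.1-fold lower number from compound 3 to compound 4 (0.03 log units; within the scatter) is expected to stay within the scatter, with no clear direction. For compound 4 the estimated value in this assay is 1.1 10^-6 cm/s, with a range from 0.55 10^-6 cm/s to 2.2 10^-6 cm/s.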

Compound 4, apparent permeability: 1.61 10^-6 cm/s
Compound 4: middle estimate off by 1.5-fold (0.17 log units), on the low side; measured number inside the range.
By their numbers in this assay, from the lowest: compounds 1, 3 and 4 (each within the scatter of the next).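

With the butyl kept on the ring nitrogen, the rhodanine group can now be read directly against the thiazolidinedione group on the aromatic carbon para to a large group: in this assay, this exchange gives a 1.4-fold higher number from compound 3 to compound 4 (0.13 log units; within the scatter) and so does not separate the two groups. The earlier pair, compound 1 and compound 3, differed in more than one place and could not isolate this exchange, whereas compound 3 and compound 4 differ only in this group. With the rhodanine group now held constant, the substituent on the ring nitrogen can also be read alone, and butyl in place of 4-chlorophenyl on that amide-type nitrogen gives a 1.6-fold higher number from compound 1 to compound 4 (0.20 log units; within the scatter), so neither single exchange shown moves the read-out beyond the usual scatter.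

From the compounds shown here alone, how a longer chain than butyl, an amine or a carboxylic acid on that ring nitrogen would read remains open, as does any group other than these two five-membered rings on the aromatic carbon. No measurement shown bears on the reason for either step.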